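The compounds below may be only part of what the source reports. "The series", "measured", "known", "first", "only" and "open" are said of these compounds alone.

Measured so far in a functional assay on CCRF-CEM cells (Homo sapiens) for antiproliferative activity, read by cell counting, with a stated time of 72 h; a higher number here means a weaker inhibitor, a lower number a stronger inhibitor:
- Compound 1 `C#C[C@@]1(O)[C@@H](CO)O[C@@H](n2cnc3c(-c4ccccc4)ncnc32)[C@@H]1O`: > 250000 nM, which is a limit of the assay and not a number.
- Compound 2 `C#C[C@@]1(O)[C@@H](CO)O[C@@H](n2cnc3c(-c4ccc(C)cc4)ncnc32)[C@@H]1O`: 154000 nM.

Within the data shown here, compound 2 holds the only actual number in this assay, so it can be ranked only against a limit. The next compound, compound 3 `C#C[C@@]1(O)[C@@H](CO)O[C@@H](n2cnc3c(-c4ccc(OC)cc4)ncnc32)[C@@H]1O`, has not yet been measured. It keeps the shared core and carries methoxy in place of methyl on an aromatic carbon, para to a large group: methoxy in place of methyl on an aromatic carbon. In other words, 4-methylphenyl becomes 4-methoxyphenyl.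

Among the measured compounds shown here, only one measured step bears on this change, the replacement of hydrogen by methyl at an aromatic carbon: an at least 1.6-fold lower number from compound 1 to compound 2 (0.21 log units; that floor lies within the scatter). Since that step gives only a floor, and one that lies within the scatter, it offers no firm size or direction for the new change. No step beyond the scatter is therefore expected in this assay. The expected step is a 1.1-fold lower number from compound 2 to compound 3 (0.04 log units; within the scatter). A reading that reports only the limit would not be surprising. For compound 3 the estimate is 140000 nM, with an expected range of 60000 nM to 250000 nM.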

Compound 3, half-maximal inhibitory concentration: > 250000 nM
Compound 3 gave a limit, no number; the forecaster's own chance of this, stated with the estimate: 30%; at least 1.7-fold (0.25 log units) between middle value and limit.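

In this assay, replacing 4-methylphenyl with 4-methoxyphenyl gives an at least 1.6-fold higher number from compound 2 to compound 3 (0.21 log units; that floor lies within the scatter), so this change at the position para to a large group has no firm size, and its floor does not separate the two compounds. Compound 3 returns a limit and not a number, and the step from compound 1 to compound 3 cannot be read because both ends are limits, so methoxy, which brings one more heavy atom and a hydrogen-bond acceptor, adds no second number at this position. Among these compounds, compound 2, at 154000 nM, therefore remains the only compound with a number. Compound 1 and compound 3 sit at the same limit: the limit of > 250000 nM in this assay, at which 2 of the 3 values shown sit.

The compounds shown leave open whether any group on this aromatic carbon can give a number well clear of that limit, and how an amine, a carboxylic acid, chlorine or a longer chain such as ethyl would read there. They also leave open whether methyl or methoxy would read differently at another carbon of the same six-membered aromatic ring.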